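Swapping the Ring at the Chain End of Compound 3

A few compounds are considered here, and "the series" means these few. Any claim that something is new, unique, unknown or untested is made for them only; others in the source may bear on it.

Of the compounds shown here, three sharing one core have been measured in a functional assay on HT-29 cells (Homo sapiens) for cytotoxicity, read by MTT assay, with a stated time of 72 h; on this read-out lower numbers stand for stronger inhibition and higher numbers for weaker inhibition. Compound 1 `COc1cc2c(Oc3ccc(NC(=O)c4cn(-c5ccccc5C)nn4)cc3F)ccnc2cc1OCCCN1CCCC1` gives 1200 nM. Compound 2 `COc1cc2c(Oc3ccc(NC(=O)c4cn(-c5ccc(Br)cc5)nn4)cc3F)ccnc2cc1OCCCN1CCCC1` gives 190 nM. Compound 3 `COc1cc2c(Oc3ccc(NC(=O)c4cn(-c5c(C)cccc5C)nn4)cc3F)ccnc2cc1OCCCN1CCCC1` gives 2240 nM, the highest of the three numbers: the nearer step is a 1.9-fold higher number from compound 1 to compound 3 (0.27 log units; within the scatter), the furthest is a 12-fold higher number from compound 2 to compound 3 (1.07 log units; beyond the scatter). The remaining measured step, a 6.3-fold lower number from compound 1 to compound 2 (0.80 log units; beyond the scatter), like the other two, changes only the group on the aromatic nitrogen.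

Compound 4 `COc1cc2c(Oc3ccc(NC(=O)c4cn(-c5c(C)cccc5C)nn4)cc3F)ccnc2cc1OCCCN1CCC(C)CC1` has not yet been measured. It differs from compound 3 in 4-methylpiperidin-1-yl in place of pyrrolidin-1-yl on a saturated chain carbon, three bonds along the chain from an oxygen on an aromatic ring. Among the compounds with values here, no measured step touches this part of the molecule, so the three measured compounds give no guide to how this assay answers to a change at the chain end. With no evidence either way, the expected step is a 1.0-fold lower number from compound 3 to compound 4 (0.01 log units; within the scatter), none beyond the scatter. Compound 4 is therefore estimated to give 2200 nM, with a range from 700 nM to 7000 nM.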

Compound 4, half-maximal inhibitory concentration: 2450 nM
The estimate for compound 4 lay 1.1-fold (0.05 log units) below the measured number; the measured number falls inside the stated range.
By their numbers in this assay, from the lowest: compound 2; then compounds 1, 3 and 4 (each within the scatter of the next, the first and the last beyond it).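

Within the data shown here, compound 3 and compound 4 give the first reading at the chain end: in this assay, 4-methylpiperidin-1-yl in place of pyrrolidin-1-yl gives a 1.1-fold higher number from compound 3 to compound 4 (0.04 log units; within the scatter) and so leaves the two compounds indistinguishable. With 2,6-dimethylphenyl on the aromatic nitrogen, then, this position holds a six-membered ring bearing a methyl as well as a five-membered ring, with no difference that the assay can resolve. Nothing shown here explains this result.

This single pair cannot tell whether the same swap would read alike with 4-bromophenyl on the aromatic nitrogen, as in compound 2, where the number is much lower. Nor does it show whether the chain end would respond to a different kind of group, such as a morpholine, a dimethylamino group or a carboxylic acid, or to a longer chain.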